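Removing the isopropyl from compound 3

The source may hold more compounds than are shown below. What is called first, only, known or untested is meant among the compounds shown, and "the series" means these compounds.

In a functional assay on HT-29 cells (Homo sapiens) for cytotoxicity (on this read-out lower numbers stand for stronger inhibition and higher numbers for weaker inhibition), compound 3 (`CCOC(=O)[C@@H](NC(=O)[C@@H](OC(=O)c1ccc(C)c2cc(OC)ccc12)[C@]1(C)CO1)C(C)C`) gives 2250 nM and lies within the scatter of compound 1 (`C[C@@]1([C@H](OC(=O)c2ccc3ccccc3c2)C(N)=O)CO1`), which gives 2600 nM on the same read-out. Compound 2 (`C[C@@]1([C@H](OC(=O)c2cnc3ccccc3n2)C(N)=O)CO1`) returns only a limit (> 25000 nM). Compound 3 therefore has just one numeric neighbour, and the two cannot be ranked.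

Compound 4 (`CCOC(=O)CNC(=O)[C@@H](OC(=O)c1ccc(C)c2cc(OC)ccc12)[C@]1(C)CO1`) carries hydrogen in place of isopropyl on a saturated chain carbon bound to an amide-type nitrogen and a carbonyl carbon. Among the measured compounds shown here, no measured pair isolates this change, so the expectation is only a small weakening (a 1.6-fold higher number from compound 3 to compound 4 (0.19 log units; within the scatter)) in this assay and possibly nothing beyond the scatter. Compound 4 is estimated at 3500 nM (expected range 1100 nM to 12000 nM).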

Compound 4, half-maximal inhibitory concentration: 2250 nM
Compound 4: the middle estimate sits 1.6-fold (0.19 log units) above what was measured; the measured number falls inside the stated range.
By their numbers in this assay, from the lowest: compounds 3, 4 and 1 (each within the scatter of the next). At a limit, above all of these: compound 2.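

In this assay, hydrogen in place of isopropyl on a saturated chain carbon bound to an amide-type nitrogen and a carbonyl carbon reads no change at the digits printed from compound 3 to compound 4 (within the scatter). Among the compounds shown here, this is the first one-place comparison, and on this read-out the isopropyl can be lost without a shift beyond the scatter. No measured property among the data bears on this step.

Still open, from the compounds shown here alone, is whether a longer chain or a benzyl group on that carbon would move the number beyond the scatter. The same holds for a carboxylic acid in place of the ethoxycarbonyl group.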